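A few compounds are considered here, and "the series" means these few. Any claim that something is new, unique, unknown or untested is made for them only; others in the source may bear on it.

Three compounds of this series have been measured in a functional assay on DU-145 cells (Homo sapiens) for inhibition, read by trypan blue exclusion, with a stated time of 96 h; a lower number here means a stronger inhibitor of growth, a higher number a weaker inhibitor of growth:

compound 1, `Cc1ccc(CS/C(=C/c2c(O)cc(O)cc2O)C(=O)c2ccc(Cl)cc2)cc1`, gives 50000 nM
compound 2, `CSc1ccc(/C=C(/SCc2ccc(C)cc2)C(=O)c2ccc(Cl)cc2)cc1`, gives 25000 nM
compound 3, `COc1ccccc1/C=C(/SCc1ccc(C)cc1)C(=O)c1ccc(Cl)cc1`, gives 10000 nM

Compound 3 holds the lowest number of the three. Its nearest neighbour is compound 2, by the step of a 2.5-fold lower number from compound 2 to compound 3 (0.40 log units; beyond the scatter), and the furthest is compound 1, by the step of a 5.0-fold lower number from compound 1 to compound 3 (0.70 log units; beyond the scatter). The remaining pair is covered by a 2.0-fold lower number from compound 1 to compound 2 (0.30 log units; within the scatter).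

Compound 4, `Cc1ccc(CS/C(=C/c2ccc(N(C)C)cc2)C(=O)c2ccc(Cl)cc2)cc1`, has not yet been measured in this assay. It differs from compound 3 in one place: 4-(dimethylamino)phenyl in place of 2-methoxyphenyl on a double-bonded chain carbon bound to a double-bonded chain carbon

All three measured steps change the same aryl group on the double-bonded chain carbon, so all three bear on this step. They were a step within the scatter, a 2.0-fold lower number from compound 1 to compound 2 (0.30 log units; within the scatter), and two modest steps, a 5.0-fold lower number from compound 1 to compound 3 (0.70 log units; beyond the scatter) and a 2.5-fold lower number from compound 2 to compound 3 (0.40 log units; beyond the scatter). Going by the values given here, no measured step leads from 2-methoxyphenyl to 4-(dimethylamino)phenyl, and the group entering resembles the 4-(methylsulfanyl)phenyl of compound 2 more than the group leaving. A small step to a higher number, likely within the scatter, is therefore expected in this assay. Compound 4 is estimated at 15000 nM, with a range from 5000 nM to 45000 nM. This estimate means an expected step of a 1.5-fold higher number from compound 3 to compound 4 (0.18 log units; within the scatter).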

Compound 4, concentration for 50% growth inhibition: > 100000 nM
Compound 4: no number, only a limit; the forecaster's own chance of this, stated with the estimate: 10%; middle value at least 6.6-fold (0.82 log units) away from the limit.
By their numbers in this assay, from the lowest: compound 3; then compounds 2 and 1 (each within the scatter of the next). At a limit, above all of these: compound 4.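

In this assay compound 4 gives no number, only a limit of the assay: the limit of > 100000 nM in this assay, at which 1 of the 4 values shown sits.

Going by these compounds alone, the earlier compounds showed only modest steps or none beyond the scatter at this position on a double-bonded chain carbon, whereas 4-(dimethylamino)phenyl in place of 2-methoxyphenyl now gives an at least 10-fold higher number from compound 3 to compound 4 (1.00 log units; beyond the scatter), the largest step so far. The exchange of dimethylamino for methylsulfanyl on an aromatic carbon also counts, with an at least 4.0-fold higher number from compound 2 to compound 4 (0.60 log units; beyond the scatter), so a change in a single group on the aromatic ring is enough to move the result beyond the scatter, while the other comparison, an at least 2.0-fold higher number from compound 1 to compound 4 (0.30 log units; that floor lies within the scatter), has a floor that lies within the scatter and does not by itself set compound 4 apart from compound 1.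

From the compounds shown here alone, the true size of all three steps stays open, since the value of compound 4 is a limit and not a number. The compounds shown also leave open whether a 4-aminophenyl or a 4-methoxyphenyl group at this position would fall with compound 3 or with compound 4, and so whether the nitrogen or the place of the group on the ring goes with the change.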